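Moving the methoxy group from compound 2 to compound 3

The compounds below may be only part of what the source reports. "The series", "measured", "known", "first", "only" and "open" are said of these compounds alone.

Compound 1 `COc1cc(C=C2C(=O)N(c3ccc(Cl)cc3)N(c3ccc(Cl)cc3)C2=O)ccc1O` gives 64900 nM
Compound 2 `COc1cccc(C=C2C(=O)N(c3ccc(Cl)cc3)N(c3ccc(Cl)cc3)C2=O)c1` gives 30200 nM

Going by the values given here, both values come from a functional assay on SMMC-7721 cells (Homo sapiens) for cytotoxicity, read by MTT assay, with a stated time of 72 h (a higher number here means a weaker inhibitor, a lower number a stronger inhibitor), and are the only numbers available for this series so far. Compound 2 holds the lower number of the two at 30200 nM in this pair, so it is the stronger inhibitor here, though both values are high.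

Compound 3 `COc1ccccc1C=C1C(=O)N(c2ccc(Cl)cc2)N(c2ccc(Cl)cc2)C1=O` has the same atoms as compound 2, joined differently: 2-methoxyphenyl in place of 3-methoxyphenyl on a double-bonded chain carbon bound to a double-bonded ring carbon is the whole change. The methoxy group stays on the ring and only its place changes.

Among the compounds with values here, one measured step bears on this, and only indirectly. The step of a 2.1-fold lower number from compound 1 to compound 2 (0.33 log units; beyond the scatter) is modest and comes from removing a hydroxy group, not from moving the methoxy group. No measured pair shows a change of methoxy place, so the data give no firm direction for this assay and no reason to expect a large step. An expected 1.2-fold higher number from compound 2 to compound 3 (0.08 log units; within the scatter) would stay within the scatter. For compound 3 the estimated value is 36000 nM with an expected range from 16000 nM to 80000 nM in this read-out.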

Compound 3, half-maximal inhibitory concentration: 25800 nM
For compound 3 the middle estimate is 1.4-fold (0.14 log units) above the measured one; low and high end bracket the measured number.
By their numbers in this assay, from the lowest: compounds 3 and 2 (each within the scatter of the next); then compound 1.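

In this assay, the 2-methoxyphenyl and 3-methoxyphenyl groups on the double-bonded chain carbon cannot be told apart: the result is a 1.2-fold lower number from compound 2 to compound 3 (0.07 log units; within the scatter) and it gives this place of the methoxy group no preferred direction. The step of a 2.5-fold lower number from compound 1 to compound 3 (0.40 log units; beyond the scatter) lies beyond the scatter and sits alongside the earlier step of a 2.1-fold lower number from compound 1 to compound 2 (0.33 log units; beyond the scatter), so among these three compounds the two without a hydroxy group both give lower numbers than compound 1, with no compound going against this. No measurement bears on why the two methoxy places read alike or why the hydroxy-bearing compound gives the higher number.

The compounds shown leave open whether an amine, a carboxylic acid or a longer chain in place of the methoxy group on this aromatic ring would shift the number beyond the scatter. Compound 3 gives 25800 nM. Also open, as far as these compounds go, is whether any change on this aromatic ring can bring the series to far lower numbers, or whether that would take a change elsewhere on the shared core.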